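Cell tolerance when the side chain grows longer

A few compounds are considered here, and "the series" means these few. Any claim that something is new, unique, unknown or untested is made for them only; others in the source may bear on it.

Compound 1 `CCNc1cc(Oc2c(OC)cc3cc(C#N)ccc3c2OC)nc(Nc2ccc(C#N)cc2)n1`: in an ADME assay on MT4 cells (Homo sapiens) for cytotoxicity, read by MTT assay, with a stated time of 5 days (a lower number here means that less compound is tolerated, a higher number that more compound is tolerated), compound 1 gives > 125000 nM, a limit of the assay.
Compound 2 `COc1cc2cc(C#N)ccc2c(OC)c1Oc1cc(NC(C)(C)C)nc(Nc2ccc(C#N)cc2)n1`: in this assay compound 2 gives > 125000 nM, again a limit of the assay.

Neither measured value is a number; both rest on (the limit of > 125000 nM in this assay, at which 2 of the 2 values shown sit). On these data alone, the step that the two limits leave unreadable from compound 1 to compound 2 therefore cannot be read, and compound 2 stands only at a limit, so its true value is unknown.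

Compound 3 `COc1cc2cc(C#N)ccc2c(OC)c1Oc1cc(NCCCOC(C)C)nc(Nc2ccc(C#N)cc2)n1` has not yet been measured. Against compound 2 it shows (3-isopropoxypropyl in place of tert-butyl on a nitrogen on an aromatic ring). Among the compounds with values here, the only measured step, a step that the two limits leave unreadable from compound 1 to compound 2, touches the same nitrogen, but its size is not readable, so it gives no guide to the direction or size of the change to compound 3. Within the data shown here, the two measured values show only that both compounds reach the limit of the assay.

The expected step is a step that the limit leaves unreadable from compound 2 to compound 3, which is to say none beyond the usual scatter. Compound 3 is therefore estimated at 150000 nM, between 60000 nM and 400000 nM, most likely reported once more only as a limit.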

Compound 3, half-maximal cytotoxic concentration: > 125000 nM
Compound 3 gave a limit, no number (the forecaster's own chance of this, stated with the estimate: 80%); the middle value is on the limit's open side.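

Within the data shown here, compound 3 also gives only a limit of the assay, so no step among compound 1, compound 2 and compound 3 can be read: the limit of > 125000 nM in this assay, at which 3 of the 3 values shown sit.

The compounds shown leave open what the true values in this assay are, and whether changing the side chain on the nitrogen makes any difference to them.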